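The compounds below may be only part of what the source reports. "The series", "measured", "known", "first", "only" and "open" are said of these compounds alone.

Compound 1 `CC(C)CC(=O)OCC1(CO)C/C(=C/CC(C(C)C)C(C)C)C(=O)O1` is one of three compounds already measured in a physicochemical assay for lipophilicity; a higher number here means a more lipophilic compound, a lower number a more polar compound. In this assay compound 1 gives 4.1, level at the digits shown with compound 2 `CC(C)C/C=C1/CC(CO)(COC(=O)CC(C(C)C)C(C)C)OC1=O`, which in this assay gives 4.1; the two read within the scatter of each other and together stand as the highest of the three numbers. Compound 3 `CC(C)=C1CC(CO)(COC(=O)CC(C(C)C)C(C)C)OC1=O` reads lowest, giving 3.2 in this assay, and its gap to compound 1 lies beyond the scatter. Compound 4 `CC(C)CC(=O)OCC1(CO)C/C(=C\CC(C(C)C)C(C)C)C(=O)O1` has not yet been measured in this assay. It differs from compound 1 in this way: the two compounds have the same atoms and bonds; at least one stereo element is drawn with a configuration in one of them and without one in the other: 1 of 2 stereo elements differ; a double bond is drawn Z in compound 1 and E in compound 4. The same atoms and bonds are kept, and only the drawn geometry of one double bond changes. No measured pair among these compounds differs in one place alone, so there is no measured step to lean on. For compound 4 the expected step is no change at the digits printed from compound 1 to compound 4 (within the scatter), nothing beyond the scatter in either direction. The estimate for compound 4 in this assay is therefore 4.1, expected to fall between 3.7 and 4.5.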

Compound 4, partition coefficient: 4.1
The estimate for compound 4 equals the measured number at the digits printed; low and high end bracket the measured number.
By their numbers in this assay, from the lowest: compound 3; then compounds 1, 2 and 4 (each within the scatter of the next).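

Going by these compounds alone, compounds 1 to 3 offered no pair differing in one place, so this pair gives the first reading of a single isolated change, the geometry of one double bond with all atoms and bonds kept. In this assay the step is no change at the digits printed from compound 1 to compound 4 (within the scatter) and so, for this double bond in this compound, the two drawn geometries cannot be told apart in this assay. One caution applies to the comparison: the fact that one of compounds 1 and 4 is drawn with a defined configuration and the other without, at the place where they differ.

The pair speaks only to geometry with this branched chain and this shared core, and a single pair sets no rule for other double bonds. On these data alone, whether the two geometries would still read alike with a carboxylic acid or an amine on that chain remains open.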